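Ortho to Meta: a Fluorophenyl Variant in the Cell Assay

The source may hold more compounds than are shown below. What is called first, only, known or untested is meant among the compounds shown, and "the series" means these compounds.

Compound 1 `COc1cc2c(Oc3ccc(NC(=O)c4nn(-c5ccccc5C)c(=O)cc4C)cc3F)ccnc2cc1OCCCN1CCCC1`: 1300 nM
Compound 2 `COc1cc2c(Oc3ccc(NC(=O)c4nn(-c5ccccc5C(F)(F)F)c(=O)cc4C)cc3F)ccnc2cc1OCCCN1CCCC1`: 130 nM
Compound 3 `COc1cc2c(Oc3ccc(NC(=O)c4nn(-c5ccccc5OC(F)(F)F)c(=O)cc4C)cc3F)ccnc2cc1OCCCN1CCCC1`: 140 nM

Three compounds share one core and differ only in the aryl group on the ring nitrogen. In a functional assay on A549 cells (Homo sapiens) for inhibition, read by MTT assay, with a stated time of 72 h (a lower number here means a stronger inhibitor, a higher number a weaker inhibitor), compound 1 gives 1300 nM, compound 2 gives 130 nM and compound 3 gives 140 nM. Compound 3 stands second of the three numbers, with compound 2 close by and compound 1 far off.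

Compound 4 `COc1cc2c(Oc3ccc(NC(=O)c4nn(-c5cccc(F)c5)c(=O)cc4C)cc3F)ccnc2cc1OCCCN1CCCC1` carries the change (3-fluorophenyl in place of 2-(trifluoromethoxy)phenyl on an aromatic nitrogen). Among the compounds with values here, no measured step matches this change directly. The steps of a 10-fold lower number from compound 1 to compound 2 (1.00 log units; beyond the scatter) and a 9.3-fold lower number from compound 1 to compound 3 (0.97 log units; beyond the scatter) show that the substituent on this phenyl ring can move the number a good deal, while a 1.1-fold higher number from compound 2 to compound 3 (0.03 log units; within the scatter) shows two such groups that do not separate. Compound 4 carries a smaller group and at a different place, so its result is uncertain. Compound 4 is expected to land between the extremes, with a step of a 3.6-fold higher number from compound 3 to compound 4 (0.55 log units; beyond the scatter) that leaves it weaker than compound 3.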

Compound 4, half-maximal inhibitory concentration: 170 nM
Compound 4: the middle estimate sits 2.9-fold (0.47 log units) above what was measured; low and high end bracket the measured number.
By their numbers in this assay, from the lowest: compounds 2, 3 and 4 (each within the scatter of the next); then compound 1.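

In this assay the 3-fluorophenyl group on the aromatic nitrogen does not separate from the two fluorinated groups already seen at this position (a 1.2-fold higher number from compound 3 to compound 4 (0.08 log units; within the scatter); a 1.3-fold higher number from compound 2 to compound 4 (0.12 log units; within the scatter)), yet it stands clearly apart from 2-methylphenyl (a 7.6-fold lower number from compound 1 to compound 4 (0.88 log units; beyond the scatter)). The number therefore does not depend on a 2-(trifluoromethoxy)phenyl or 2-(trifluoromethyl)phenyl group: 3-fluorophenyl, with fewer heavy atoms than the first of these, serves as well, and among the four compounds only compound 1 stands apart. Nothing shown here explains this result.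

Going by these compounds, how an amine or a carboxylic acid on this phenyl ring would read in this assay remains open. So does whether any aryl group is needed on this nitrogen, since every compound shown carries a phenyl ring there.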